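Taking the methyl off the furan of compound 2

A few compounds are considered here, and "the series" means these few. Any claim that something is new, unique, unknown or untested is made for them only; others in the source may bear on it.

In a physicochemical assay for solubility, read by mass spectrometry, in phosphate buffer, with a stated time of 24 h, at pH 3 (on this read-out lower numbers stand for lower solubility and higher numbers for higher solubility), compound 2 (`Cc1occc1C(=O)N1CCC(NC(=O)Nc2ccc(OC(F)(F)F)cc2)CC1`) gives 7.7 ug/mL. Among the compounds with values here, compound 3 (`O=C(Nc1ccc(C(F)(F)F)cc1)NC1CCN(C(=O)C2=COCC2)CC1`) gives 8.2 ug/mL, a number within the usual scatter of the one for compound 2. Compound 1 (`Cc1occc1C(=O)N1CCC(NC(=O)Nc2ccc(C(F)(F)F)cc2)CC1`) gives 2.1 ug/mL, and both of the others stand clear of it.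

Compound 4 (`O=C(Nc1ccc(OC(F)(F)F)cc1)NC1CCN(C(=O)c2ccoc2)CC1`) keeps the trifluoromethoxy group of compound 2 and changes the other end of the molecule: hydrogen in place of methyl on an aromatic carbon. In words, hydrogen replaces methyl on an aromatic carbon, turning 2-methylfuran-3-yl into furan-3-yl.

Within the data shown here, no measured pair isolates this change. The step of a 3.7-fold higher number from compound 1 to compound 2 (0.56 log units; beyond the scatter) is the swap of trifluoromethyl for trifluoromethoxy, so it says nothing direct about the methyl. The closer guide is the step of a 3.9-fold higher number from compound 1 to compound 3 (0.59 log units; beyond the scatter), where the 2-methylfuran-3-yl group was also replaced, and the methyl went with it. That guide is only partial, since the incoming ring there is non-aromatic and the aromatic furan stays in compound 4.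

A modest upward move in this assay is therefore expected, smaller than that guide: a 2.2-fold higher number from compound 2 to compound 4 (0.34 log units; beyond the scatter). For compound 4 the estimated value is 17 ug/mL, with an expected range from 7 ug/mL to 40 ug/mL.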

Compound 4, solubility: 26 ug/mL
Beside the measured number, compound 4's estimate is 1.5-fold (0.18 log units) below it; low and high end bracket the measured number.
By their numbers in this assay, from the lowest: compound 1; then compounds 2 and 3 (each within the scatter of the next); then compound 4.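

Within the data shown here, the step of a 3.4-fold higher number from compound 2 to compound 4 (0.53 log units; beyond the scatter) in this assay is the first to change only this one spot, an aromatic carbon of the furan next to the ring oxygen, where hydrogen replaces methyl. The earlier step of a 3.9-fold higher number from compound 1 to compound 3 (0.59 log units; beyond the scatter) took the methyl away together with the aromatic furan, so it could not separate the two changes; here the aromatic ring stays, and the loss of the single methyl carbon is enough on its own to carry the number beyond the scatter, at least with trifluoromethoxy at the other end of the molecule. The compounds shown carry no measurement that gives a reason for this move.

As far as these compounds go, whether hydrogen in place of methyl gives a similar step with trifluoromethyl at the other end remains open, since this change has been read only once, on a single pair of compounds. Also open, from the compounds shown here alone, is how the number responds to other groups on this same carbon, such as a chlorine atom, an ethyl chain or an aminomethyl group.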